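The source may report more compounds than this note shows. Statements on the series, on what has been measured and on what is new or still open speak of the compounds shown alone.

In an ADME assay on MDBK cells (Bos taurus) for cytotoxicity, read by MTT assay, with a stated time of 96 h (a higher number here means that more compound is tolerated, a lower number that less compound is tolerated), compound 1 `COc1cccc(NC(=S)Nc2cccc(C(F)(F)F)c2)c1` gives 52000 nM. Compound 2 `CC(=O)NC(=S)Nc1cccc(C(F)(F)F)c1` reaches only a limit of the assay, > 100000 nM. Compound 3 `FC(F)(F)c1cccc(NC(=S)Nc2cccc(Br)c2)c1` gives 10000 nM, the lowest number of the three, which makes it the least tolerated so far.

Two measured steps lead to compound 3. Putting bromo in place of methoxy on an aromatic carbon gives a 5.2-fold lower number from compound 1 to compound 3 (0.72 log units; beyond the scatter). Putting 3-bromophenyl in place of acetyl on an amide-type nitrogen gives an at least 10-fold lower number from compound 2 to compound 3 (1.00 log units; beyond the scatter), a step whose size rests on a limit at one end.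

Compound 4 `FC(F)(F)c1cccc(NC(=S)Nc2ccccc2Br)c1` has the same atoms as compound 3, joined differently: 2-bromophenyl stands in place of 3-bromophenyl on an amide-type nitrogen, (2-bromophenyl in place of 3-bromophenyl on an amide-type nitrogen).

Neither measured step moves a bromo group around its ring, so both bear on this change only indirectly. Each of them replaced one group with a different one, while here the bromophenyl group is kept. A smaller move than a 5.2-fold lower number from compound 1 to compound 3 (0.72 log units; beyond the scatter) is therefore expected, and most likely none beyond the scatter, in either direction. The expected change is a 1.2-fold higher number from compound 3 to compound 4 (0.08 log units; within the scatter). For compound 4 the estimated value is 12000 nM, with an expected range of 5000 nM to 35000 nM.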

Compound 4, half-maximal cytotoxic concentration: > 100000 nM
Compound 4 was reported as a limit (the forecaster's own chance of this, stated with the estimate: 5%); at least 8.3-fold (0.92 log units) between middle value and limit.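

Moving the bromo group on its ring, with the same atoms kept, is enough on its own to shift the result in this assay: 2-bromophenyl in place of 3-bromophenyl on an amide-type nitrogen gives an at least 10-fold higher number from compound 3 to compound 4 (1.00 log units; beyond the scatter). The earlier steps shown here each replaced one group with a different one, so they could not show that the place of the bromo matters even when the group and its atom counts stay the same. Compound 4 gives only a limit of the assay, so the true size of this step remains unknown, and the step between compound 2 and compound 4 cannot be read, since both of its ends are limits: the limit of > 100000 nM in this assay, at which 2 of the 4 values shown sit.

The compounds shown leave open how much compound 4 is tolerated in absolute terms, and so how large the effect of this move really is. They also leave open whether the change belongs to the bromo group itself or would also appear with a chloro or a methyl group in place of the bromo in 2-bromophenyl.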